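The source may hold more compounds than are shown below. What is called first, only, known or untested is meant among the compounds shown, and "the series" means these compounds.

Measured compounds:
compound 1, `COc1ccc(C)cc1N1C(=O)CSC1c1cccc(C(=O)NCCCCc2ccccc2)c1`, 42%
compound 2, `COc1ccc(F)cc1N1C(=O)CSC1c1cccc(C(=O)NCCCCc2ccccc2)c1`, 46%

In a functional assay on HOS cells (Homo sapiens) for inhibition, read by CCK-8 assay, with a stated time of 72 h, tested at 1 uM (a higher number here means more inhibition at the concentration tested (going by the name of the read-out), a lower number less inhibition), compound 1 gives 42% and compound 2 gives 46%. Among the compounds with values here, the single step between them, a number 4 percentage points higher from compound 1 to compound 2 (within the scatter), leaves the two values within the usual scatter, so compound 2 stands on a par with compound 1 and neither can be set above the other on these numbers.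

Compound 3, `Cc1cccc(N2C(=O)CSC2c2cccc(C(=O)NCCCCc3ccccc3)c2)c1`, has not yet been measured in this assay. It differs from compound 2 at the aryl group on an amide-type nitrogen in a ring: 3-methylphenyl in place of 5-fluoro-2-methoxyphenyl on an amide-type nitrogen in a ring. Within the data shown here, the only measured step that bears on this part of the molecule is a number 4 percentage points higher from compound 1 to compound 2 (within the scatter), which exchanged one substituent on that same aryl ring without moving the value beyond the scatter. Among the measured compounds shown here, that step kept the methoxy group, whereas the change to compound 3 removes it and leaves a 3-methylphenyl; no measured pair covers that loss. For the measured compounds named here, with one flat step as the only guide, no move beyond the scatter is expected in either direction, and the wider range reflects the untested change. Compound 3 is therefore estimated at 40%, between 20% and 60%, an expected step of a number 6 percentage points lower from compound 2 to compound 3 (within the scatter) that stays within the scatter.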

Compound 3, a percentage reported as inhibition, at one concentration (the size of the read-out at that concentration, not a potency): 84%
The estimate for compound 3 lay 44 percentage points below the measured number; measured number outside the range, above it.
By their numbers in this assay, from the lowest: compounds 1 and 2 (each within the scatter of the next); then compound 3.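

In this assay, within the data shown here, the aryl group on the amide-type nitrogen in a ring proves far from indifferent, since 3-methylphenyl in place of 5-fluoro-2-methoxyphenyl gives a number 38 percentage points higher from compound 2 to compound 3 (beyond the scatter) and so ends the flat picture left by the only earlier step at this group. The cleaner comparison is hydrogen in place of methoxy on an aromatic carbon, a single exchange that gives a number 42 percentage points higher from compound 1 to compound 3 (beyond the scatter) with the methyl group kept, whereas the earlier exchange of methyl for fluoro with the methoxy group kept gave only a number 4 percentage points higher from compound 1 to compound 2 (within the scatter) and stayed within the scatter; among these three compounds, the large rise therefore goes with the loss of the methoxy group and not with the swap of the other substituent. Nothing available here explains why removing the methoxy group goes with so large a rise.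

The compounds shown leave open whether the rise requires a bare hydrogen at that carbon or would survive a hydroxy, ethoxy or chloro group there. They also leave open what the methyl group of compound 3 adds, as none of them carries an unsubstituted phenyl group on that nitrogen.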